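The source may hold more compounds than are shown below. What is called first, only, known or untested is meant among the compounds shown, and "the series" means these compounds.

Compound 1 `CCCCCN1CCN(c2nc3ccccc3n2CCOCC)CC1` gives 30 nM
Compound 2 `COCCCn1c(N2CCN(C)CC2)nc2ccccc21` gives 860 nM
Compound 3 `CCCC(C)Cn1c(N2CCN(C)CC2)nc2ccccc21` gives 500 nM

In a functional assay on ileum for inhibition of histamine H1 receptor (Cavia porcellus) (on this read-out higher numbers stand for weaker inhibition and lower numbers for stronger inhibition), compound 1 stands lowest of the three numbers measured, ahead of compound 3 by a gap beyond the scatter and ahead of compound 2 by a wider one. Among the compounds with values here, only one step between compounds differing in a single place has been measured, a 1.7-fold lower number from compound 2 to compound 3 (0.24 log units; within the scatter), and it lies within the scatter; it alters the group on the saturated chain carbon bound to an aromatic nitrogen, which is not the part of the molecule changed here.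

Compound 4 `CCCN1CCN(c2nc3ccccc3n2CCOCC)CC1` differs from compound 1 as hydrogen in place of ethyl on a saturated chain carbon, three bonds along the chain from an amine nitrogen in a ring. Within the data shown here, no measured pair isolates this change. Compound 2 and compound 3 carry a methyl on the ring amine nitrogen, but each also differs from compound 1 on the aromatic nitrogen side, so their higher numbers cannot be read as the effect of a shorter chain alone. Still, with compound 2 at 860 nM and compound 3 at 500 nM, both well above compound 1, a shorter chain is expected to go with a higher number, the step from compound 1 to compound 4 being estimated as a 3.3-fold higher number from compound 1 to compound 4 (0.52 log units; beyond the scatter). Compound 4 is therefore estimated at 100 nM, within a range of 30 nM to 400 nM.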

Compound 4, half-maximal inhibitory concentration: 16 nM
The estimate for compound 4 lay 6.3-fold (0.80 log units) above the measured number, and the stated range ends above it.
By their numbers in this assay, from the lowest: compounds 4 and 1 (each within the scatter of the next); then compounds 3 and 2 (each within the scatter of the next).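

In this assay, the exchange of ethyl for hydrogen on a saturated chain carbon, three bonds along the chain from an amine nitrogen in a ring, gives a 1.9-fold lower number from compound 1 to compound 4 (0.27 log units; within the scatter); the same difference reads as pentyl to propyl. Within the data shown here, this is the first measured pair that isolates this position, and it shows that removing those two carbons leaves the number within the scatter, so compound 1 and compound 4 cannot be told apart in this read-out and the outer end of the pentyl chain has no readable effect on it. Nothing given here bears on why the number holds when the chain is cut back.

The compounds shown leave open how far this tolerance extends, since one pair cannot say whether methyl in place of the propyl of compound 4, with the rest of that compound unchanged, would keep the number in the same range. As far as these compounds go, it also remains open whether a longer chain such as hexyl, or a propyl chain ending in a carboxylic acid or an amine, would do so.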